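This account rests on a few compounds, and the source may have more. Where it says the series, first, only, none or still open, it means among the compounds named here.

Compound 1 `COC(=O)CCNC(=O)[C@@H]1O[P@](=O)(OCOC(=O)c2ccnn2C)OCC1(C)C` in an ADME assay on blood (Homo sapiens) for pharmacokinetics; on this read-out higher numbers stand for a longer-lived compound and lower numbers for a shorter-lived compound: < 0.16 h.
Compound 2 `CCOC(=O)CCNC(=O)[C@@H]1O[P@@](=O)(OCOC(=O)C(C)(C)C)OCC1(C)C` in this assay: 0.28 h.

For compound 1 the reported value is a limit of the assay, not a number, and it sits at the limit of < 0.16 h in this assay, at which 1 of the 2 values shown sits. Compound 2 gives a measured value. Compound 3 `CCc1cc(C(=O)OCO[P@]2(=O)OCC(C)(C)[C@H](C(=O)NCCC(=O)OC)O2)n(C)n1` differs from compound 1 by ethyl in place of hydrogen on an aromatic carbon. For the measured compounds named here, no single-change step between measured compounds is available, so the size of this change in this assay is uncertain; a step within the scatter is expected, with compound 3 remaining short-lived. The estimate for compound 3 in this assay is 0.15 h, between 0.05 h and 0.5 h. This corresponds to an expected step that the limit leaves unreadable from compound 1 to compound 3.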

Compound 3, half-life: < 0.16 h
Compound 3: a limit, no number; the forecaster's own chance of this, stated with the estimate: 50%; the middle value does not contradict the limit.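

In this assay compound 3 gives < 0.16 h, a limit and not a number. For the compounds shown here, compound 1 gives < 0.16 h, also a limit, and no step between the two can be read. The compounds shown leave open what ethyl in place of hydrogen does to the half-life.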